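A few compounds are considered here, and "the series" means these few. Any claim that something is new, unique, unknown or untested is made for them only; others in the source may bear on it.

Measured compounds in an ADME assay on MT4 cells (Homo sapiens) for cytotoxicity, read by MTT assay, with a stated time of 96 h; on this read-out higher numbers stand for lower toxicity in this test and lower numbers for higher toxicity in this test:

compound 1, `CC(=O)Oc1ccc2c(C)cc(=O)oc2c1Cc1c[nH]c2ccccc12`: 100000 nM
compound 2, `COc1ccc2[nH]cc(Cc3c(OC(C)=O)ccc4c(C)cc(=O)oc34)c2c1`: 72000 nM
compound 3, `CCCOc1ccc2c(C)cc(=O)oc2c1CN1CCc2ccccc2C1`: > 100000 nM

Compound 1 stands highest of the two numbers available; its nearest neighbour is compound 2, with a 1.4-fold lower number from compound 1 to compound 2 (0.14 log units; within the scatter). For compound 3 this assay reports a limit rather than a number, (the limit of > 100000 nM in this assay, at which 1 of the 3 values shown sits). For the measured compounds named here, the only change with a measured step, methoxy in place of hydrogen on an aromatic carbon, sits on a different part of the shared core and moved the read-out by no more than the scatter.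

Compound 4, `CC(=O)Oc1ccc2c(C)cc(=O)oc2c1Cc1c(C)[nH]c2ccccc12`, differs from compound 1 by methyl in place of hydrogen on an aromatic carbon. Going by the values given here, no measured step covers a methyl added at this place, so the step from compound 1 to compound 4 in this assay has no direct precedent. Among the compounds with values here, the one measured step, a 1.4-fold lower number from compound 1 to compound 2 (0.14 log units; within the scatter), being within the scatter, gives no ground to expect a shift in either direction beyond the scatter. Compound 4 is therefore expected to give about 90000 nM, from 45000 nM to 180000 nM. This estimate corresponds to a 1.1-fold lower number from compound 1 to compound 4 (0.05 log units; within the scatter), an expected step within the scatter.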

Compound 4, half-maximal cytotoxic concentration: 41000 nM
Estimate against measurement, compound 4: 2.2-fold (0.34 log units) above; the measured number lies below the stated range.
By their numbers in this assay, from the lowest: compounds 4, 2 and 1 (each within the scatter of the next, the first and the last beyond it).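

In this assay, methyl in place of hydrogen on an aromatic carbon next to the ring nitrogen gives a 2.4-fold lower number from compound 1 to compound 4 (0.39 log units; beyond the scatter), a modest step and the only one in the series beyond the scatter. This place on the five-membered aromatic ring, next to the ring atom that bears a large group, therefore responds on this read-out, in the direction of higher toxicity in this test, whereas the methoxy change, a 1.4-fold lower number from compound 1 to compound 2 (0.14 log units; within the scatter), stayed within the scatter. No measured property at hand bears on this step.

As far as these compounds go, whether an ethyl group, a longer chain, an amine or a carboxylic acid at the same place would move the number further remains open. Also open, from the compounds shown here alone, is whether methyl here gives a similar step on compound 2, which carries the methoxy group.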